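This account rests on a few compounds, and the source may have more. Where it says the series, first, only, none or still open, it means among the compounds named here.

Two compounds of a shared core were tested in a functional assay on HT-1080 cells (Homo sapiens), read by transwell migration, with a stated time of 24 h, tested at 0.1 uM; on this read-out higher numbers stand for a weaker effect at the one concentration tested and lower numbers for a stronger effect. Compound 1 `CC(=O)OCc1ccc2oc(=O)c(C(=O)Sc3cccc(Cl)c3)cc2c1` gives 76.5% in this assay. Compound 2 `CCC(=O)OCc1ccc2oc(=O)c(C(=O)Oc3cccc(Br)c3)cc2c1` gives 84.4%. Those two numbers sit within the usual scatter of each other, so neither stands apart from the other.

Compound 3 `CC(C)C(=O)OCc1ccc2oc(=O)c(C(=O)Oc3cccc(Br)c3)cc2c1` has not yet been measured. It differs from compound 2 in one place: methyl in place of hydrogen on a saturated chain carbon bound to a carbonyl carbon and a saturated chain carbon. Within the data shown here, no measured pair shows what this change does, so no step beyond the scatter is expected from compound 2 to compound 3 in this assay; the expected step is a number 0.4 percentage points lower from compound 2 to compound 3 (within the scatter). Compound 3 is therefore estimated at 84%, within 70% to 96%.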

Compound 3, a percentage reported as activity, at one concentration (the size of the read-out at that concentration, not a potency): 54.4%
Compound 3: the middle estimate sits 29.6 percentage points above what was measured; measured number below the stated range.
By their numbers in this assay, from the lowest: compound 3; then compounds 1 and 2 (each within the scatter of the next).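

Replacing propanoyl with isopropylcarbonyl, through methyl in place of hydrogen on a saturated chain carbon bound to a carbonyl carbon and a saturated chain carbon, gives a number 30 percentage points lower from compound 2 to compound 3 (beyond the scatter) in this assay and so a stronger effect at the one concentration tested. Among these compounds, this is the first measured sign that this chain carbon responds to change, and a single added carbon is enough. No available measurement bears on the cause of this step. On these data alone, whether a longer chain or an amine on this carbon would shift the read-out further remains open. So does whether the same methyl would act alike on compound 1.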